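A few compounds are considered here, and "the series" means these few. Any claim that something is new, unique, unknown or untested is made for them only; others in the source may bear on it.

In an ADME assay on microsomes from liver (Mus musculus) for metabolic stability (on this read-out lower numbers stand for a shorter-lived compound and higher numbers for a longer-lived compound), compound 3 `CC(C)C(c1ccc(-c2ccc3cccc(F)c3c2)[nH]c1=O)N1CCCCC1=O` gives 0.0967 h. Compound 1 `CC(C)C(c1ccc(-c2ccc3cccc(F)c3c2)[nH]c1=O)N1CCCCS1(=O)=O` gives 0.0733 h, within the scatter of compound 3, so the two stand level on the numbers in hand. Compound 2 `CC(C)C(Cc1nnc[nH]1)c1ccc(-c2ccc3cccc(F)c3c2)[nH]c1=O` returns only a limit, < 0.0667 h.

The step under consideration leads to compound 4 `CC(C)C(c1nnc[nH]1)c1ccc(-c2ccc3cccc(F)c3c2)[nH]c1=O`: 4H-1,2,4-triazol-3-yl in place of 2-oxopiperidin-1-yl on a saturated chain carbon bound to an aromatic carbon and a saturated chain carbon. The closest measured comparison is the exchange of (4H-1,2,4-triazol-3-yl)methyl for 2-oxopiperidin-1-yl, seen as an at least 1.4-fold higher number from compound 2 to compound 3 (0.16 log units; that floor lies within the scatter). Its size is bounded on one side only, and that floor lies within the scatter. The other two steps at the same saturated chain carbon, a 1.3-fold higher number from compound 1 to compound 3 (0.12 log units; within the scatter) and an at least 1.0-fold lower number from compound 1 to compound 2 (0.04 log units; that floor lies within the scatter), are also not resolved from the scatter. None of the three therefore supports a clear move, and no step beyond the scatter is expected. Any shift is expected to be towards a shorter-lived compound, since the nearest relative of compound 4 is compound 2, which stands at the limit of < 0.0667 h. A reading of compound 4 at that same limit is a real possibility.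

The expected step is a 1.4-fold lower number from compound 3 to compound 4 (0.14 log units; within the scatter). For compound 4 the estimate is 0.07 h, with an expected range of 0.04 h to 0.14 h.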

Compound 4, half-life: 0.213 h
For compound 4 the middle estimate is 3.0-fold (0.48 log units) below the measured one, outside the stated range (above it).
By their numbers in this assay, from the lowest: compounds 1 and 3 (each within the scatter of the next); then compound 4. At a limit, below all of these: compound 2.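

In this assay, among these compounds, 4H-1,2,4-triazol-3-yl on this saturated chain carbon gives the first steps at the position that clear the scatter, against both six-membered non-aromatic rings (a 2.2-fold higher number from compound 3 to compound 4 (0.34 log units; beyond the scatter); a 2.9-fold higher number from compound 1 to compound 4 (0.46 log units; beyond the scatter)). The same triazole ring carried as (4H-1,2,4-triazol-3-yl)methyl does not share this result (an at least 3.1-fold higher number from compound 2 to compound 4 (0.50 log units; beyond the scatter)), so among these compounds the longer-lived reading goes with the ring sitting directly on the chain carbon, not with the presence of the ring alone. The size of that last step is a floor only, as compound 2 is read as a limit of the assay: the limit of < 0.0667 h in this assay, at which 1 of the 4 values shown sits.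

The compounds shown leave open whether the result is particular to the 1,2,4-triazole or extends to other five-membered aromatic rings attached directly at this carbon, such as an imidazole, a pyrazole or a tetrazole. They also leave open how a non-ring group at the same carbon, such as a primary amide, a carboxylic acid or an amine, would read in this assay, and a longer chain between the triazole and this carbon is equally untested here.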